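The source may hold more compounds than are shown below. What is called first, only, known or untested is meant among the compounds shown, and "the series" means these compounds.

Measured compounds in a functional assay on RAW264.7 cells (Mus musculus) for inhibition, read by Griess assay, with stated times of 1 h and 24 h; on this read-out higher numbers stand for weaker inhibition and lower numbers for stronger inhibition:
compound 1 `COc1ccc(Nc2nc(/C=C/c3cc(OC)c(OC)c(OC)c3)nc3ccsc23)cc1` — 10700 nM
compound 2 `COc1cc(/C=C/c2nc(Nc3ccc(O)cc3)c3sccc3n2)cc(OC)c1OC` — 4070 nM
compound 3 `COc1cc(/C=C/c2nc(NCc3ccc(C)cc3)c3sccc3n2)cc(OC)c1OC` — 1860 nM

Compound 3 stands at the lowest number of the three in this assay: from compound 2 the step is a 2.2-fold lower number from compound 2 to compound 3 (0.34 log units; beyond the scatter), and from compound 1 it is a 5.8-fold lower number from compound 1 to compound 3 (0.76 log units; beyond the scatter), both beyond the scatter. Compound 4 `COc1cc(/C=C/c2nc(NCc3ccc(Cl)cc3)c3sccc3n2)cc(OC)c1OC` differs from compound 3 in one place: chloro in place of methyl on an aromatic carbon. Within the data shown here, no measured step tests this kind of exchange. The two steps that reach compound 3 replace the whole group on the nitrogen, and the remaining step, a 2.6-fold lower number from compound 1 to compound 2 (0.42 log units; beyond the scatter), exchanges methyl for hydrogen on an oxygen, which is a different change. On the shared 4-methylbenzyl to 4-chlorobenzyl exchange there is no direct evidence, so in this assay compound 4 is expected to sit close to compound 3, with a step of a 1.0-fold lower number from compound 3 to compound 4 (0.01 log units; within the scatter) that should stay within the scatter. The estimate for compound 4 in this assay is 1800 nM, with a range from 700 nM to 4500 nM.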

Compound 4, half-maximal inhibitory concentration: 9050 nM
Compound 4: middle estimate off by 5.0-fold (0.70 log units), on the low side; the whole stated range lies below it.
By their numbers in this assay, from the lowest: compound 3; then compound 2; then compounds 4 and 1 (each within the scatter of the next).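

In this assay, compound 4 shows that this place on the benzyl group is not indifferent: chloro in place of methyl, one heavy atom for another, gives a 4.9-fold higher number from compound 3 to compound 4 (0.69 log units; beyond the scatter), so the low number of compound 3 does not come with every 4-substituted benzyl group. With 4-chlorobenzyl on the nitrogen, the lead over the phenyl-substituted compounds is lost, as shown by a 2.2-fold higher number from compound 2 to compound 4 (0.35 log units; beyond the scatter) and by a 1.2-fold lower number from compound 1 to compound 4 (0.07 log units; within the scatter), which leaves compound 1 and compound 4 indistinguishable. Nothing measured here accounts for the gap between methyl and chloro.

The compounds shown leave open whether methyl is unusual at this place, or whether fluoro, ethyl or dimethylamino would sit nearer compound 3 or compound 4. They also leave open whether the same exchange would have a similar effect on 4-methylphenyl, where no methylene separates the ring from the nitrogen.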